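The compounds below may be only part of what the source reports. "The series", "measured", "known", "first", "only" and "open" are said of these compounds alone.

Compound 1 `Cc1ccc(C#N)c(OC(C)(C)C2OCC(C/C=C\CCC(=O)O)C(c3cccnc3)O2)c1`: in an assay for inhibition of prostacyclin synthase (Homo sapiens), using microsomes (on this read-out higher numbers stand for weaker inhibition and lower numbers for stronger inhibition), compound 1 gives > 100000 nM, which is a limit of the assay.
Compound 2 `CC(C)(Oc1ccccc1F)C1OCC(C/C=C\CCC(=O)O)C(c2cccnc2)O1`: in this assay compound 2 gives < 1000 nM, also a limit.
Compound 3 `CC(C)(Oc1ccccc1[N+](=O)[O-])C1OCC(C/C=C\CCC(=O)O)C(c2cccnc2)O1`: in this assay compound 3 gives < 1000 nM, a limit as well.

Compound 3 thus stands at the lower limit, where two of the three values sit (the limit of < 1000 nM in this assay, at which 2 of the 3 values shown sit); the remaining value sits at the upper limit (the limit of > 100000 nM in this assay, at which 1 of the 3 values shown sits). The unmeasured compound 4 `COc1ccc(OC(C)(C)C2OCC(C/C=C\CCC(=O)O)C(c3cccnc3)O2)c([N+](=O)[O-])c1` differs from compound 3 by methoxy in place of hydrogen on an aromatic carbon. Of the measured steps, an at least 100-fold lower number from compound 1 to compound 2 (2.00 log units; beyond the scatter) and an at least 100-fold lower number from compound 1 to compound 3 (2.00 log units; beyond the scatter) each exchange the whole aryl group, while a step that the two limits leave unreadable from compound 2 to compound 3. Among the measured compounds shown here, no measured step isolates a substituent added to the 2-nitrophenyl group. Compound 4 is therefore expected to stay near the limit, with an estimated step that the limit leaves unreadable from compound 3 to compound 4. The estimate for compound 4 in this assay is 400 nM, in the range 50 nM to 3000 nM.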

Compound 4, half-maximal inhibitory concentration: 23000 nM
The estimate for compound 4 lay 58-fold (1.76 log units) below the measured number, and the stated range ends below it.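

In this assay, among the compounds shown here, methoxy on an aromatic carbon, meta to a nitro group and para to a large group, is the first single added substituent with a readable effect, giving an at least 23-fold higher number from compound 3 to compound 4 (1.36 log units; beyond the scatter). Against the other aryl groups, 4-methoxy-2-nitrophenyl gives an at least 23-fold higher number from compound 2 to compound 4 (1.36 log units; beyond the scatter) and an at least 4.3-fold lower number from compound 1 to compound 4 (0.63 log units; beyond the scatter), which places compound 4 between the two limits. The first two of these steps are bounds resting on a limit: the limit of < 1000 nM in this assay, at which 2 of the 4 values shown sit.

From the compounds shown here alone, whether the loss belongs to methoxy or to any group at this carbon stays open. A hydroxyl, a methyl or a chlorine there would separate the two.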